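The source may hold more compounds than are shown below. What is called first, only, known or untested is meant among the compounds shown, and "the series" means these compounds.

Of the compounds shown here, three built on one shared core have been measured in a functional assay on MV4-11 cells (Homo sapiens) for antiproliferative activity, with a stated time of 6 days, tested at 6.25 uM; on this read-out higher numbers stand for a stronger effect at the one concentration tested and lower numbers for a weaker effect. Compound 1 `CNC(=O)N1CCCc2ccc(NC(=O)c3cccc(-c4ccccc4)c3)cc21` carries a phenyl group on an aromatic carbon of the outer ring and gives 1.39%. Compound 2 `CNC(=O)N1CCCc2ccc(NC(=O)c3cccc(-c4cc[nH]n4)c3)cc21` carries 1H-pyrazol-3-yl in that place and gives 89.7%. Compound 3 `CNC(=O)N1CCCc2ccc(NC(=O)c3cccc(-c4cn[nH]c4)c3)cc21` carries 1H-pyrazol-4-yl there and gives 77.7%. Among the three numbers compound 3 stands second: a number 76.3 percentage points higher from compound 1 to compound 3 (beyond the scatter), while a number 12 percentage points lower from compound 2 to compound 3 (beyond the scatter).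

Compound 4 `CNC(=O)N1CCCc2ccc(NC(=O)c3cccc(-c4cnn(C(C)=O)c4)c3)cc21` is not yet measured. It differs from compound 3 in a single place: acetyl in place of hydrogen on an aromatic nitrogen. Seen one bond further out, the change reads 1H-pyrazol-4-yl to 1-acetyl-1H-pyrazol-4-yl.

No measured step exchanges a group on the ring nitrogen, so nothing shown tests this change directly. The steps that come nearest are a number 76.3 percentage points higher from compound 1 to compound 3 (beyond the scatter), a large gain when the pyrazole ring enters, and a number 12 percentage points lower from compound 2 to compound 3 (beyond the scatter), a modest shift when only its attachment point moves. The ring itself therefore carries most of the effect, and capping its nitrogen is an untested change with wide uncertainty.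

A moderate decrease is expected for compound 4, a number 27.7 percentage points lower from compound 3 to compound 4 (beyond the scatter), giving an estimate of 50% within a range from 10% to 85%.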

Compound 4, a percentage reported as inhibition, at one concentration (the size of the read-out at that concentration, not a potency): 82%
The estimate for compound 4 lay 32 percentage points below the measured number, and the stated range covers the measured number.
By their numbers in this assay, from the lowest: compound 1; then compounds 3, 4 and 2 (each within the scatter of the next, the first and the last beyond it).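

Capping the ring nitrogen does not cost the effect seen in this assay: acetyl in place of hydrogen on the aromatic nitrogen gives a number 4.3 percentage points higher from compound 3 to compound 4 (within the scatter), so the two compounds cannot be told apart. The hydrogen on that nitrogen is therefore not needed for this read-out, and the 3 heavy atoms of the acetyl group are tolerated at this position, with a number 7.7 percentage points lower from compound 2 to compound 4 (within the scatter) also lying inside the usual spread and a number 80.6 percentage points higher from compound 1 to compound 4 (beyond the scatter) showing that the large gain over the phenyl group remains. No supporting data are available to explain why this change is tolerated.

As far as these compounds go, how much more this nitrogen can carry remains open, as a small methyl group, a longer alkyl chain or a chain ending in an amine or a carboxylic acid could each give a different result. With only one concentration tested, this assay also cannot show whether compound 2, compound 3 and compound 4 would differ in the strength of their effect at lower concentrations.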